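Sulfonamide Chain in Place of Cyclopropyl on the Amine

A few compounds are considered here, and "the series" means these few. Any claim that something is new, unique, unknown or untested is made for them only; others in the source may bear on it.

Three compounds on a shared core have been examined in an ADME assay on cells (Homo sapiens) for cytotoxicity, read by polymerase chain reaction, with a stated time of 3 days; on this read-out lower numbers stand for higher toxicity in this test and higher numbers for lower toxicity in this test. Compound 1 `Nc1nc(Cl)c(-c2nccs2)c(N[C@@H]2C[C@H](CO)[C@@H](O)[C@H]2O)n1` reaches only the limit of this assay, giving > 25000 nM. Compound 2 `Cc1nc(N)nc(N[C@@H]2C[C@H](CO)[C@@H](O)[C@H]2O)c1-c1nc2ccccc2s1` gives 4000 nM, and compound 3 `Cc1nc(NCC2CC2)nc(N[C@@H]2C[C@H](CO)[C@@H](O)[C@H]2O)c1-c1nc2ccccc2s1` gives 8000 nM. Among the measured compounds shown here, the one change joining them, a 2.0-fold higher number from compound 2 to compound 3 (0.30 log units; within the scatter), alters the substituent on the exocyclic amine without moving the number beyond the scatter. Compound 3 therefore holds the higher of the two numbers shown, but its nearest neighbour, compound 2, is within the scatter of it, so no order between them can be claimed.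

Compound 4 `Cc1nc(NCCNS(C)(=O)=O)nc(N[C@@H]2C[C@H](CO)[C@@H](O)[C@H]2O)c1-c1nc2ccccc2s1` is the next step from compound 3: (methanesulfonamido)methyl in place of cyclopropyl on a saturated chain carbon bound to a nitrogen on an aromatic ring. For the measured compounds named here, the only measured step that touches this same position is the one from compound 2 to compound 3, and it stayed within the scatter. With nothing pointing to a larger shift, the step of a 1.1-fold higher number from compound 3 to compound 4 (0.05 log units; within the scatter) is expected to stay within the scatter as well. Compound 4 is thus estimated at 9000 nM, within a range from 3500 nM to 25000 nM.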

Compound 4, half-maximal cytotoxic concentration: > 25000 nM
Compound 4 gave a limit, no number (the forecaster's own chance of this, stated with the estimate: 20%); middle value at least 2.7-fold (0.44 log units) from the limit.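

Replacing cyclopropyl with (methanesulfonamido)methyl on this chain gave an at least 3.1-fold higher number from compound 3 to compound 4 (0.49 log units; beyond the scatter). In this assay, this position can therefore carry a change that lies beyond the scatter, which a 2.0-fold higher number from compound 2 to compound 3 (0.30 log units; within the scatter) had not shown, and the same holds against the unsubstituted amine, with an at least 6.2-fold higher number from compound 2 to compound 4 (0.79 log units; beyond the scatter). Both steps give only a lower bound on the size of the change, because compound 4 sits at a limit and not at a number: the limit of > 25000 nM in this assay, at which 2 of the 4 values shown sit.

The compounds shown leave open how far the number would rise without that limit, and whether the shift belongs to the methanesulfonamide or to the longer chain. An acetamide, a hydroxyl or a carboxylic acid at the end of the same ethyl chain, or a plain longer alkyl chain, would bear on that question.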